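The source may report more compounds than this note shows. Statements on the series, on what has been measured and on what is new or still open speak of the compounds shown alone.

Compound 1 `COC(=O)C1=C(Nc2ccccc2F)O/C(=C\c2c[nH]c3ncccc23)C1=O` gives 10% in an ADME assay on microsomes from liver (Rattus norvegicus) for metabolic stability, read by LC-MS, using NADPH, with a stated time of 30 min, tested at 1 uM; a lower number here means that less of the compound is left, a higher number that more of the compound is left.
Compound 2 `COC(=O)C1=C(Nc2ccccc2Cl)O/C(=C\c2c[nH]c3ncccc23)C1=O` gives 58% in this assay.
Compound 3 `COC(=O)C1=C(Nc2ccc(F)cc2)O/C(=C\c2c[nH]c3ncccc23)C1=O` gives 25% in this assay.

Among these three numbers compound 3 stands second highest: compound 1 is the nearest to it, and compound 2 the furthest. Both gaps lie beyond the usual scatter, so the order of the three is real.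

Compound 4 `COC(=O)C1=C(Nc2ccccc2C)O/C(=C\c2c[nH]c3ncccc23)C1=O` is the next compound of the series. It differs from compound 3 in one place: 2-methylphenyl in place of 4-fluorophenyl on an amine nitrogen. Two measured steps end at compound 3 and bear directly on this change. Each of them also swaps the ring on that amine nitrogen: a number 15 percentage points higher from compound 1 to compound 3 (beyond the scatter) and a number 33 percentage points lower from compound 2 to compound 3 (beyond the scatter). They point in opposite directions. A third step shows how much a single swap on that ring can move the number: a number 48 percentage points higher from compound 1 to compound 2 (beyond the scatter). Taken together, these steps say that exchanging the ring on the amine nitrogen reliably shifts the result beyond the scatter, but they do not agree on the direction, since a 2-fluorophenyl sits below compound 3 while a 2-chlorophenyl sits well above it.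

The estimate for compound 4 is therefore 35%, with a wide range from 10% to 65%. This estimate implies a step of a number 10 percentage points higher from compound 3 to compound 4 (within the scatter) and expects a change of uncertain sign.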

Compound 4, percent of the compound remaining: 24%
Estimate against measurement, compound 4: 11 percentage points above; the range from low to high includes it.
By their numbers in this assay, from the lowest: compound 1; then compounds 4 and 3 (each within the scatter of the next); then compound 2.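

In this assay, 2-methylphenyl in place of 4-fluorophenyl on the amine nitrogen gives a number 1 percentage points lower from compound 3 to compound 4 (within the scatter) and so leaves these two rings indistinguishable, even though they differ in both the group they carry and where it sits. Changing only the group on the ring, and keeping its place, separates the series more clearly: methyl in place of chloro gives a number 34 percentage points lower from compound 2 to compound 4 (beyond the scatter) and is a large step, while methyl in place of fluoro gives a number 14 percentage points higher from compound 1 to compound 4 (beyond the scatter) and is a modest one. The high number of compound 2 therefore does not come with every ring of this 2-substituted kind, as compound 1 and compound 4 both stand well below it, and among these four compounds only the 2-chlorophenyl ring stands clear of all the others.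

Still open, going by these compounds, is whether a 2-bromophenyl or 2-methoxyphenyl ring would stand with compound 2 or with compound 4, and whether a 4-chlorophenyl ring would keep the high number seen with chloro. Nothing given here explains why chloro stands apart from fluoro and methyl.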